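Series notes: bromo in place of phenyl on the shared core

The source may hold more compounds than are shown below. What is called first, only, known or untested is meant among the compounds shown, and "the series" means these compounds.

Measured compounds and their values in an assay on CHO cells for displacement of a labelled ligand from adenosine receptor A3 (Homo sapiens), read by scintillation counting, tested at 10 uM; on this read-out lower numbers stand for less inhibition and higher numbers for more inhibition at the one concentration tested (going by the name of the read-out):
compound 1, `CC(C)Cc1csc(N)c1C(=O)c1ccc(Cl)cc1`: 1%
compound 2, `CC(C)(C)c1csc(N)c1C(=O)c1ccc(Cl)cc1`: 1%
compound 3, `Cc1c(-c2ccccc2)sc(N)c1C(=O)c1ccc(Cl)cc1`: 1%

Compound 3 stands level with compounds 1 and 2 at the digits shown; the gap to compound 1 and the gap to compound 2 are both within the scatter. For the measured compounds named here, the only single-place step measured so far, no change at the digits printed from compound 1 to compound 2 (within the scatter), is a change on an aromatic carbon of the shared core and also stays within the scatter.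

Compound 4, `Cc1c(Br)sc(N)c1C(=O)c1ccc(Cl)cc1`, is not yet measured. It differs from compound 3 as follows: bromo in place of phenyl on an aromatic carbon. This change sits on the same five-membered aromatic ring as the step from compound 1 to compound 2, but swaps a ring for a single bromine, so that step bears on it only loosely. Nothing measured in this set moves beyond the scatter, and every compound sits at the low end of the read-out. The expectation for compound 4 is therefore a step of a number 1 percentage points higher from compound 3 to compound 4 (within the scatter) that stays within the scatter. Compound 4 is estimated at 2%, with a range from -6% to 12%.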

Compound 4, a percentage reported as inhibition, at one concentration (the size of the read-out at that concentration, not a potency): 1%
Estimate against measurement, compound 4: 1 percentage points above, within the range that was stated.
By their numbers in this assay, from the lowest: compounds 1, 2, 3 and 4 (each within the scatter of the next).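

In this assay, replacing phenyl with bromo on the aromatic carbon next to the ring sulfur gives no change at the digits printed from compound 3 to compound 4 (within the scatter) and so leaves the read-out unmoved across a change from 6 heavy atoms and a six-membered aromatic ring to 1 heavy atom and no ring. The earlier single-place step only exchanged isobutyl for tert-butyl, whereas this one shows that even removing the whole phenyl ring from this carbon brings no shift beyond the scatter, although with both compounds at the low end of the read-out it says little about how the position would behave in a compound showing clear inhibition. No measurement in hand offers an explanation for this flat result.

The compounds shown leave open whether an amine or a carboxylic acid on this carbon would lift the read-out off the low end. Equally open, going by these compounds, is what a longer chain in place of the methyl group on the neighbouring ring atom would do in this assay.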